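Aryl swap on the saturated ring carbon, compound 2 to 4

This account rests on a few compounds, and the source may have more. Where it says the series, first, only, none or still open, it means among the compounds named here.

Compound 2 `COc1cc(N2C(=O)[C@@H](Oc3ccccc3)[C@H]2c2cccc3ccccc23)cc(OC)c1OC` gives 53000 nM in a functional assay on MCF7 cells (Homo sapiens) for antiproliferative activity, read by MTT assay, with stated times of 24 h and 72 h (a higher number here means a weaker inhibitor, a lower number a stronger inhibitor), the second highest of three numbers. Compound 1 `COc1ccc([C@@H]2[C@H](Oc3ccccc3)C(=O)N2c2cc(OC)c(OC)c(OC)c2)cc1` gives 35000 nM and compound 3 `CCOC(=O)/C=C/c1ccc([C@@H]2[C@H](Oc3ccccc3)C(=O)N2c2cc(OC)c(OC)c(OC)c2)cc1` gives 87000 nM; neither differs from compound 2 beyond the scatter. Compound 4 `COc1cc(N2C(=O)[C@@H](Oc3ccccc3)[C@H]2c2cccc(O)c2)cc(OC)c1OC` carries 3-hydroxyphenyl in place of naphthalen-1-yl on a saturated ring carbon. Going by the values given here, the one step already made at this place is a 1.5-fold higher number from compound 1 to compound 2 (0.18 log units; within the scatter), an exchange of one aryl group for another on a saturated ring carbon with no change beyond the scatter; the step of a 2.5-fold higher number from compound 1 to compound 3 (0.40 log units; beyond the scatter) sits on an aromatic carbon instead and bears less here. No hydroxyphenyl has yet been measured in this series, so the expectation rests on that single aryl exchange. The step expected here is a 1.3-fold lower number from compound 2 to compound 4 (0.12 log units; within the scatter). Compound 4 is estimated at 40000 nM, within 15000 nM to 110000 nM.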

Compound 4, half-maximal inhibitory concentration: 54000 nM
The estimate for compound 4 lay 1.4-fold (0.13 log units) below the measured number; the measured number falls inside the stated range.
By their numbers in this assay, from the lowest: compounds 1, 2, 4 and 3 (each within the scatter of the next, the first and the last beyond it).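

In this assay the saturated ring carbon tolerates a hydroxyphenyl with no change beyond the scatter, with a 1.0-fold higher number from compound 2 to compound 4 (0.01 log units; within the scatter) and a 1.5-fold higher number from compound 1 to compound 4 (0.19 log units; within the scatter). The 3-hydroxyphenyl brings a hydrogen-bond donor and loses an aromatic ring relative to naphthalen-1-yl, yet compounds 1, 2 and 4 do not separate. Nothing measured here accounts for this flat response.

On these data alone, whether an aminophenyl or a carboxyphenyl on this carbon would give a step beyond the scatter stays open. So does whether exchanging the phenoxy group would.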